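The source may hold more compounds than are shown below. What is called first, only, known or untested is meant among the compounds shown, and "the series" means these compounds.

Measured so far in a functional assay on MCF7 cells (Homo sapiens) for cytotoxicity, read by MTT assay, with a stated time of 72 h; a lower number here means a stronger inhibitor, a higher number a weaker inhibitor:
compound 1 `CN1CCN(Cc2nnc(-c3cc(S(N)(=O)=O)c(SCc4ccccc4)cc3Cl)o2)CC1` gives 75000 nM;
compound 2 `CC(C)(O)c1cn(Cc2nnc(-c3cc(S(N)(=O)=O)c(SCc4ccccc4)cc3Cl)o2)nn1` gives 168000 nM;
compound 3 `NS(=O)(=O)c1cc(-c2nnc(Cn3cc(-c4ccccc4)nn3)o2)c(Cl)cc1SCc1ccccc1` gives 170000 nM.

Compound 3 carries the highest of the three numbers shown, yet its value and that of compound 2 sit within the scatter of each other (a 1.0-fold higher number from compound 2 to compound 3 (0.01 log units; within the scatter)), so the two cannot be told apart. Against compound 1 the gap is real but modest: a 2.3-fold higher number from compound 1 to compound 3 (0.36 log units; beyond the scatter). Compound 4 `NS(=O)(=O)c1cc(-c2nnc(/C=C/c3cccc(Cl)c3)o2)c(Cl)cc1SCc1ccccc1` keeps the shared core of compound 3 and alters the group on the five-membered ring: 2-(3-chlorophenyl)ethenyl in place of (4-phenyl-1H-1,2,3-triazol-1-yl)methyl on an aromatic carbon. Among the measured compounds shown here, none of the measured steps involves an exchange of this kind. The steps that exist swap one nitrogen-containing group for another (a 2.2-fold higher number from compound 1 to compound 2 (0.35 log units; beyond the scatter) and a 2.3-fold higher number from compound 1 to compound 3 (0.36 log units; beyond the scatter)) or change the substituent within the triazolyl group (a 1.0-fold higher number from compound 2 to compound 3 (0.01 log units; within the scatter)); all were modest or within the scatter, and all three compounds cluster at weak inhibition. For the measured compounds named here, with no direct precedent, the step expected in this assay is a 1.4-fold lower number from compound 3 to compound 4 (0.15 log units; within the scatter), that is, nothing beyond the scatter. Compound 4 is therefore estimated at 120000 nM, with a range from 40000 nM to 350000 nM.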

Compound 4, half-maximal inhibitory concentration: 11000 nM
Beside the measured number, compound 4's estimate is 11-fold (1.04 log units) above it; measured number below the stated range.
By their numbers in this assay, from the lowest: compound 4; then compound 1; then compounds 2 and 3 (each within the scatter of the next).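

In this assay, compounds 1, 2 and 3 all hold a saturated chain carbon at this position on the five-membered aromatic ring, and changing the nitrogen-linked group on that carbon moved the number only modestly or not beyond the scatter. Replacing the whole arm with 2-(3-chlorophenyl)ethenyl has a much larger effect, giving a 15-fold lower number from compound 3 to compound 4 (1.19 log units; beyond the scatter) and a 15-fold lower number from compound 2 to compound 4 (1.18 log units; beyond the scatter), and it still lowers the number against the lowest earlier value, with a 6.8-fold lower number from compound 1 to compound 4 (0.83 log units; beyond the scatter). This position can therefore shift the number far more than the earlier compounds suggested, but nothing shown explains the drop.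

The exchange alters several features at once, so the double bond, the chlorine and the loss of the triazole cannot be separated. Either 2-phenylethenyl or 2-(3-chlorophenyl)ethyl at this position would help to separate them.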